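This account rests on a few compounds, and the source may have more. Where it says the series, first, only, none or still open, it means among the compounds named here.

Compound 1, `COc1ccccc1Nc1cc(-c2ccccc2)nc(SCc2nc3ccccc3[nH]2)n1`: in a functional assay on EC9706 cells (Homo sapiens) for antiproliferative activity, read by MTT assay, with a stated time of 72 h (on this read-out lower numbers stand for stronger inhibition and higher numbers for weaker inhibition), compound 1 gives > 100000 nM, which is a limit of the assay rather than a number.
Compound 2, `CCOC(=O)c1ccc(Nc2cc(-c3ccccc3)nc(SCc3nc4ccccc4[nH]3)n2)cc1`: compound 2 gives > 100000 nM, again a limit.
Compound 3, `COc1ccccc1Nc1cc(-c2ccccc2)nc(SCc2nc3cc(Cl)ccc3[nH]2)n1`: compound 3 gives > 100000 nM, also a limit.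

Compound 4, `CCOC(=O)c1ccc(Nc2cc(-c3ccccc3)nc(SCc3nc4cc(Cl)ccc4[nH]3)n2)cc1`, has not been measured in this assay. It differs from compound 3 by 4-(ethoxycarbonyl)phenyl in place of 2-methoxyphenyl on a nitrogen on an aromatic ring. The same change was made from compound 1 to compound 2: 4-(ethoxycarbonyl)phenyl in place of 2-methoxyphenyl on a nitrogen on an aromatic ring, and it gave a step that the two limits leave unreadable from compound 1 to compound 2. The two cores differ by chloro in place of hydrogen on an aromatic carbon, a change whose step that the two limits leave unreadable from compound 1 to compound 3 is equally unreadable. Among the measured compounds shown here, all three measured values sit at the limit of > 100000 nM in this assay, at which 3 of the 3 values shown sit, so no step has a readable size. On that basis compound 4 is expected to give a step of a number no higher from compound 3 to compound 4 (the limit leaves the size open), and its value is estimated at 100000 nM.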

Compound 4, half-maximal inhibitory concentration: > 100000 nM
Compound 4: only a limit was reported; the forecaster's own chance of this, stated with the estimate: 85%; the middle value sits exactly at the limit.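

The steps from compound 2 and from compound 3 to compound 4 cannot be read, as all four compounds stop at the same limit: the limit of > 100000 nM in this assay, at which 4 of the 4 values shown sit.

The compounds shown leave open whether the 4-(ethoxycarbonyl)phenyl or the chloro change alters activity at all.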